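This account rests on a few compounds, and the source may have more. Where it says the series, first, only, none or still open, it means among the compounds named here.

Going by the values given here, compound 2 `COc1ccc(Nc2nc(SCc3cn(CC(=O)NC(=O)Nc4ccccn4)nn3)nc(-c3ccc(C(C)C)cc3)c2C#N)cc1` gives the lowest of the two numbers so far in a functional assay on B16-F10 cells (Mus musculus) for inhibition, read by MTT assay, with a stated time of 72 h (a lower number here means a stronger inhibitor, a higher number a weaker inhibitor), at 360 nM, while compound 1 `CC(C)c1ccc(-c2nc(SCc3cn(CC(=O)NC(=O)Nc4ccccn4)nn3)nc(Nc3cccc(Cl)c3)c2C#N)cc1` gives 1130 nM. Among the compounds with values here, the single measured step, a 3.1-fold lower number from compound 1 to compound 2 (0.50 log units; beyond the scatter), came from changing the group on a nitrogen on an aromatic ring. Compound 3 `Cc1ccccc1Nc1nc(SCc2cn(CC(=O)NC(=O)Nc3ccccn3)nn2)nc(-c2ccc(C(C)C)cc2)c1C#N` changes that same group again: 2-methylphenyl in place of 4-methoxyphenyl on a nitrogen on an aromatic ring. Within the data shown here, no measured step covers this particular exchange, so the one step available bears on it only by showing that changes at this nitrogen can shift this assay by a modest amount in either direction. Compound 3 is therefore expected to land near compound 2, with a modest movement toward a higher number, as a 1.8-fold higher number from compound 2 to compound 3 (0.26 log units; within the scatter). Compound 3 is estimated at 650 nM, with a range from 250 nM to 1700 nM.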

Compound 3, half-maximal inhibitory concentration: 18600 nM
Compound 3: middle estimate off by 29-fold (1.46 log units), on the low side; measured number above the stated range.
By their numbers in this assay, from the lowest: compound 2; then compound 1; then compound 3.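

In this assay, the group on this nitrogen turns out to control far more than the one earlier exchange indicated, and 2-methylphenyl is the poor choice among the three aryl groups shown. Entering in place of 4-methoxyphenyl, it gives a large loss (a 52-fold higher number from compound 2 to compound 3 (1.71 log units; beyond the scatter)), and in place of 3-chlorophenyl it also gives a large loss (a 16-fold higher number from compound 1 to compound 3 (1.22 log units; beyond the scatter)), so both earlier groups stand well clear of it, while the step between those two is only modest. Nothing measured here explains why this one exchange costs so much.

The three compounds leave open whether the loss follows the methyl group itself or where it sits on the phenyl ring. A 4-methylphenyl or a 2-methoxyphenyl group on this nitrogen would separate those two readings, and an unsubstituted phenyl would give a reference for all three.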